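The source may hold more compounds than are shown below. What is called first, only, known or untested is meant among the compounds shown, and "the series" means these compounds.

Measured in a functional assay on HCT-116 cells (Homo sapiens) for antiproliferative activity, with a stated time of 72 h; a lower number here means a stronger inhibitor, a higher number a weaker inhibitor:

- compound 1 `CCCC#Cc1cc([C@@H]2O[C@H](CO)[C@@H](O)[C@H]2O)n2ncnc(N)c12`: 200 nM
- compound 2 `Nc1ncnn2c([C@@H]3O[C@H](CO)[C@@H](O)[C@H]3O)cc(C#Cc3ccccc3)c12`: 46900 nM

Of these two, compound 2 has the higher number, at 46900 nM, so it is the weaker inhibitor in this assay. The next structure to consider is compound 3 `Nc1ncnn2c([C@@H]3O[C@H](CO)[C@@H](O)[C@H]3O)cc(-c3ccccc3)c12`, which has not yet been measured. The change is phenyl in place of 2-phenylethynyl on an aromatic carbon. The triple bond is thus lost while a phenyl ring remains.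

Among the measured compounds shown here, only one measured step bears on this, and only indirectly: a 230-fold higher number from compound 1 to compound 2 (2.37 log units; beyond the scatter). That large step shows that the group carried on the triple bond can matter greatly in this series. For the measured compounds named here, it does not show what happens when the triple bond itself is removed, and no measured compound tests that. Compound 3 keeps the phenyl ring of compound 2, so it is expected to stay far closer to compound 2 than to compound 1, perhaps slightly stronger. The estimate amounts to a 3.1-fold lower number from compound 2 to compound 3 (0.50 log units; beyond the scatter), a modest expected step towards a lower number. For compound 3 the estimated value is 15000 nM, with an expected range from 1500 nM to 60000 nM.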

Compound 3, half-maximal inhibitory concentration: 82600 nM
The estimate for compound 3 lay 5.5-fold (0.74 log units) below the measured number; the whole stated range lies below it.
By their numbers in this assay, from the lowest: compound 1; then compounds 2 and 3 (each within the scatter of the next).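

In this assay, removing the triple bond so that the phenyl ring sits directly on the aromatic carbon gives a 1.8-fold higher number from compound 2 to compound 3 (0.25 log units; within the scatter) and so leaves compound 2 and compound 3 indistinguishable, which means that with a phenyl ring at this position, the triple bond makes no measurable difference. Replacing pent-1-yn-1-yl with phenyl at the same position gives a 410-fold higher number from compound 1 to compound 3 (2.62 log units; beyond the scatter) and is beyond the scatter, as is a 230-fold higher number from compound 1 to compound 2 (2.37 log units; beyond the scatter) for the change that keeps the triple bond, so among these three compounds only compound 1, the one without a phenyl ring, has a much lower number. No measurement at hand explains this difference.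

The compounds shown leave open whether the triple bond matters when the group carries a chain instead of a ring, which a saturated pentyl group or a pent-1-en-1-yl group at this position would test. They also leave open how much of the chain on the triple bond is needed, and how a shorter chain such as methyl, or a chain ending in an amine, would compare with the propyl of compound 1.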